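The source may hold more compounds than are shown below. What is called first, only, known or untested is meant among the compounds shown, and "the series" means these compounds.

Measured compounds in a functional assay on HeLa cells (Homo sapiens) for antiproliferative activity, read by MTT assay, with a stated time of 72 h; a lower number here means a stronger inhibitor, a higher number a weaker inhibitor:
- compound 1, `O=C(Nc1ccc(Cl)c(-c2nnc3c(Cl)cccn23)c1)c1ccccn1`; compound 1 gives 75500 nM.
- compound 2, `Cc1nc(C(=O)Nc2ccc(Cl)c(-c3nnc4c(Cl)cccn34)c2)cs1`; compound 2 gives 79800 nM.
- compound 3, `O=C(Nc1ccc(Cl)c(-c2nnc3c(Cl)cccn23)c1)c1cccnc1`; compound 3 reaches only the assay limit, > 100000 nM, which is the limit of > 100000 nM in this assay, at which 1 of the 3 values shown sits.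

Compound 3 therefore stands at the ceiling of the range measured; its value is a limit, not a number. The steps of a 1.1-fold higher number from compound 1 to compound 2 (0.02 log units; within the scatter), an at least 1.3-fold higher number from compound 1 to compound 3 (0.12 log units; that floor lies within the scatter) and an at least 1.2-fold higher number from compound 2 to compound 3 (0.09 log units; that floor lies within the scatter) all lie within the scatter, so the three amide substituents seen so far sit together. Compound 4, `O=C(Nc1ccc(Cl)c(-c2nnc3c(Cl)cccn23)c1)c1ccc(Cl)cc1`, differs from compound 3 by 4-chlorophenyl in place of pyridin-3-yl on a carbonyl carbon. None of the measured steps touches a carbon-only ring, and none gives a reason to expect a move beyond the scatter in this assay in either direction. Compound 4 is thus expected near 100000 nM, with a range of 40000 nM to 250000 nM, and the step of a number no higher from compound 3 to compound 4 (the limit leaves the size open) is expected to stay within the scatter.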

Compound 4, half-maximal inhibitory concentration: > 100000 nM
Compound 4: a limit, no number; the forecaster's own chance of this, stated with the estimate: 60%; the middle value lies on the limit itself.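

In this assay compound 4 gives > 100000 nM, which is a limit and not a number. Even with 4-chlorophenyl, a ring of carbon only, on the carbonyl carbon, the series gains no measurable activity, and a second compound now rests on the ceiling: (the limit of > 100000 nM in this assay, at which 2 of the 4 values shown sit). The readable steps (an at least 1.2-fold higher number from compound 2 to compound 4 (0.09 log units; that floor lies within the scatter)) and (an at least 1.3-fold higher number from compound 1 to compound 4 (0.12 log units; that floor lies within the scatter)) separate no amide substituent from the others, and the step between compound 3 and compound 4 cannot be read.

Open, from the compounds shown here alone, is whether an aliphatic amine, a carboxylic acid or a longer chain on this carbonyl carbon would give a clearly lower number. Also open, going by these compounds, is whether any change to the shared core would do so.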